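The source may report more compounds than this note shows. Statements on the series, on what has been measured and on what is new or still open speak of the compounds shown alone.

Compound 1 `O=C1NCCN1c1ccc(S(=O)(=O)Nc2ccccc2)cc1` is the reference point. Within the data shown here, in a functional assay on M21 cells (Homo sapiens) for antiproliferative activity, read by sulforhodamine B assay, with a stated time of 48 h (a higher number here means a weaker inhibitor, a lower number a stronger inhibitor), compound 1 gives 200 nM, the only number among the three values shown. Compound 2 `CC(C)Cc1ccc(NS(=O)(=O)c2ccc(N3CCNC3=O)cc2)cc1` carries isobutyl in place of hydrogen on an aromatic carbon; in this assay compound 2 reaches only the limit > 1000 nM. Compound 3 `CCCCCCOc1ccc(NS(=O)(=O)c2ccc(N3CCNC3=O)cc2)cc1` carries hexyloxy in place of hydrogen on an aromatic carbon; in this assay compound 3 likewise stops at the limit > 1000 nM. The two measured steps were an at least 5.0-fold higher number from compound 1 to compound 2 (0.69 log units; beyond the scatter) and an at least 5.0-fold higher number from compound 1 to compound 3 (0.69 log units; beyond the scatter). Compound 4 `COc1cccc(NS(=O)(=O)c2ccc(N3CCNC3=O)cc2)c1` brings the change (methoxy in place of hydrogen on an aromatic carbon). Both earlier additions on that ring weakened compound 1, so the step of a 2.5-fold higher number from compound 1 to compound 4 (0.40 log units; beyond the scatter) is expected to run in the same direction. Compound 4 is accordingly estimated at 500 nM, within 150 nM to 2000 nM.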

Compound 4, half-maximal inhibitory concentration: 65 nM
Compound 4: middle estimate off by 7.7-fold (0.89 log units), on the high side; the whole stated range lies above it.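

In this assay, methoxy meta to a large group gives a 3.1-fold lower number from compound 1 to compound 4 (0.49 log units; beyond the scatter), so the phenyl ring of compound 1 can take an added group with a gain rather than a loss. This is the only addition shown on that ring that goes this way, and compound 2 and compound 3 go against it. Those two are known only as limits, not numbers: the limit of > 1000 nM in this assay, at which 2 of the 4 values shown sit.

The compounds shown leave open whether the gain follows the methoxy group itself or its place on the ring, and how a hydroxyl, a fluorine or an ethoxy group would read there.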